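Swapping the ester for a ketone on the shared core

A few compounds are considered here, and "the series" means these few. Any claim that something is new, unique, unknown or untested is made for them only; others in the source may bear on it.

Of the compounds shown here, three built on the same core have been tested in a functional assay on RAW264.7 cells (Mus musculus), read by fluorescence; on this read-out lower numbers stand for stronger inhibition and higher numbers for weaker inhibition. Compound 1 `CCOC(=O)C1=CCCCC1S(=O)(=O)Cc1cccc(Cl)c1Cl` gives 65 nM. Compound 2 `CCOC(=O)C1=CCCCC1S(=O)(=O)Cc1coc2ccccc12` gives 106 nM in this assay. Compound 3 `CCCCOC(=O)C1=CCCCC1S(=O)(=O)Cc1ccc(F)cc1Cl` gives 103 nM in this assay, the second highest of the three numbers, yet every gap among these three compounds lies within the usual scatter, so none of them can be set apart from the others on this evidence.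

Compound 4 `CCCC(=O)C1=CCCCC1S(=O)(=O)Cc1ccc(F)cc1Cl` is not yet measured. Compared with compound 3 the change is propyl in place of butoxy on a carbonyl carbon; the ester becomes a ketone, with one fewer carbon in the chain and the chain oxygen gone. Among the compounds with values here, no measured pair shows this change, so its effect in this assay is unknown. The expectation is a step from compound 3 to compound 4 of a 1.6-fold higher number from compound 3 to compound 4 (0.19 log units; within the scatter), small and towards a higher number, not clearly beyond the scatter. Compound 4 is therefore estimated at 160 nM in this assay, within a range of 50 nM to 500 nM.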

Compound 4, half-maximal inhibitory concentration: 11 nM
For compound 4 the middle estimate is 15-fold (1.16 log units) above the measured one, and the stated range ends above it.
By their numbers in this assay, from the lowest: compound 4; then compounds 1, 3 and 2 (each within the scatter of the next).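

Within the data shown here, the group on the carbonyl carbon matters in this assay in a way the earlier compounds could not show, since no two of them differed in one place and all their gaps stayed within the scatter. Keeping everything else fixed and placing propyl where butoxy stood, which turns the ester into a ketone, gives a 9.4-fold lower number from compound 3 to compound 4 (0.97 log units; beyond the scatter) and so marks this position as one where a single change moves the number clearly. No measurement at hand accounts for this step.

The change removes the chain oxygen and shortens the chain together, so the compounds shown cannot tell which of the two counts. A pentyl or an ethyl chain on the same carbonyl carbon, or an amide in place of the ketone, would begin to separate them.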